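Ethyl in place of propylsulfanyl on the shared core

A few compounds are considered here, and "the series" means these few. Any claim that something is new, unique, unknown or untested is made for them only; others in the source may bear on it.

The three measured compounds share one core. Compound 1 is `CCCSc1nc(N)c2nc(O)n(Cc3ccccc3)c2n1`, compound 3 is `CCCCSc1nc(N)c2nc(O)n(Cc3ccccc3)c2n1` and compound 2 is `Nc1nc(SCc2ccccc2)nc2c1nc(O)n2Cc1ccccc1`. In a functional assay on the whole organism for activation, with Mus musculus as the target (on this read-out lower numbers stand for an effect already at smaller amounts and higher numbers for an effect only at larger amounts of compound), compound 1 gives 0.1 mg/kg, the lowest of the two numbers in hand. Compound 3 gives 0.3 mg/kg, a change of a 3.0-fold higher number from compound 1 to compound 3 (0.48 log units; beyond the scatter). For compound 2 the assay reports only a limit, > 1 mg/kg; of compound 2 nothing beyond the limit of > 1 mg/kg in this assay, at which 1 of the 3 values shown sits, is known. Against compound 1 this is an at least 10-fold higher number from compound 1 to compound 2 (1.00 log units; beyond the scatter), and against compound 3 it is an at least 3.3-fold lower number from compound 2 to compound 3 (0.52 log units; beyond the scatter). Within these three, each enlargement of the group on the saturated chain carbon bound to a sulfur gave a higher number.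

Compound 4 is `CCc1nc(N)c2nc(O)n(Cc3ccccc3)c2n1`. It differs from compound 1 by ethyl in place of propylsulfanyl on an aromatic carbon. Going by the values given here, none of the measured steps removes the sulfur or shortens the group; all of them enlarge it, so the shrinkage in compound 4 has no direct precedent, and the direction of its effect cannot be read from the steps in hand. The measured steps make the number in this assay sensitive to this position, so a step beyond the scatter is expected, most likely toward a higher number. For compound 4 the expected step is a 3.0-fold higher number from compound 1 to compound 4 (0.48 log units; beyond the scatter). The estimate for compound 4 in this assay is 0.3 mg/kg, with a range from 0.1 mg/kg to 1 mg/kg.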

Compound 4, minimum effective dose: 3 mg/kg
Estimate against measurement, compound 4: 10-fold (1.00 log units) below; measured number above the stated range.
By their numbers in this assay, from the lowest: compound 1; then compound 3; then compound 4.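

Up to now, only enlargement of the group on this aromatic carbon had been seen, and in this assay the change from propylsulfanyl to the smaller, sulfur-free ethyl also moves the number upward, with a 30-fold higher number from compound 1 to compound 4 (1.48 log units; beyond the scatter). The ethyl change from butylsulfanyl points the same way, with a 10-fold higher number from compound 3 to compound 4 (1.00 log units; beyond the scatter), so compound 4 goes against the earlier reading that a larger group gives a higher number, and among the readable values propylsulfanyl in compound 1 gives the lowest number, with both butylsulfanyl and ethyl higher. The step from compound 2 to compound 4 cannot be read, and the value of compound 2 is a limit and not a number: the limit of > 1 mg/kg in this assay, at which 1 of the 4 values shown sits.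

The change to ethyl removes the sulfur and shortens the group in one step, so the two contributions stay unseparated; propyl placed directly on this aromatic carbon, or ethylsulfanyl, would divide them. From the compounds shown here alone, whether sulfur itself is needed also stays open, and a propoxy or propylamino group in the same place would test that.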